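A few compounds are considered here, and "the series" means these few. Any claim that something is new, unique, unknown or untested is made for them only; others in the source may bear on it.

Among the compounds with values here, compound 1 `CC(C)(C)c1ccc(C(CC(=O)O)NC(=O)c2ccc(F)cc2)cc1` is the first of two close analogues built on one core. In a functional assay on MDA-MB-436 cells (Homo sapiens) for antiproliferative activity, read by MTT assay, with a stated time of 24 h (a higher number here means a weaker inhibitor, a lower number a stronger inhibitor), compound 1 gives > 100000 nM, which is a limit of the assay rather than a number. Compound 2 `CC(C)(C)c1ccc(C(CC(=O)O)NC(=O)c2ccc(C(F)(F)F)cc2)cc1` carries trifluoromethyl in place of fluoro on an aromatic carbon and in this assay compound 2 gives 82300 nM. Between the two there is an at least 1.2-fold lower number from compound 1 to compound 2 (0.08 log units; that floor lies within the scatter); the starting point of that step rests on (the limit of > 100000 nM in this assay, at which 2 of the 3 values shown sit), so only its floor can be read.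

Compound 3 `O=C(O)CC(NC(=O)c1ccc(F)cc1)c1ccccc1F` belongs to a second core; how it differs from the core of compound 1 is not broken down here. In this assay compound 3 gives > 100000 nM, again a limit of the assay.

Compound 4 `O=C(O)CC(NC(=O)c1ccc(C(F)(F)F)cc1)c1ccccc1F` is the same change made on this second core: trifluoromethyl in place of fluoro on an aromatic carbon. The place is described in the same words for both pairs, so it is the same change. What compound 4 will do in this assay is not yet known. Resting on the step of compound 2, which is an at least 1.2-fold lower number from compound 1 to compound 2 (0.08 log units; that floor lies within the scatter), the step from compound 3 is expected to be an at least 1.1-fold lower number from compound 3 to compound 4 (0.04 log units; that floor lies within the scatter). Compound 4 is therefore estimated at 90000 nM, with a range from 40000 nM to 200000 nM, and it may well again give only a limit.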

Compound 4, half-maximal inhibitory concentration: 66800 nM
The estimate for compound 4 lay 1.3-fold (0.13 log units) above the measured number; the measured number falls inside the stated range.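

On the second core, the step in this assay is an at least 1.4-fold lower number from compound 3 to compound 4 (0.17 log units; that floor lies within the scatter). Set beside the step on the first core, the result reads: the same change on two cores in this assay, an at least 1.2-fold lower number (0.08 log units; that floor lies within the scatter) from compound 1 to compound 2 and an at least 1.4-fold lower number (0.17 log units; that floor lies within the scatter) from compound 3 to compound 4; the limit leaves it open whether they differ. The two steps do not disagree, but this does not show that the change carries from one core to the other with the same size, or that it moves the number beyond the scatter on either core, because each step starts from a limit of the assay rather than a number: the limit of > 100000 nM in this assay, at which 2 of the 4 values shown sit.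

The compounds shown leave open whether a group other than fluoro or trifluoromethyl on that aromatic carbon, such as a nitrile or an amine, would behave alike on both cores. They also leave open what the step would be from a starting compound with a measured number instead of a limit, which is what a size comparison between the cores would need.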